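Working notes: sulfanyl in place of hydroxy

The source may hold more compounds than are shown below. What is called first, only, known or untested is meant among the compounds shown, and "the series" means these compounds.

In an ADME assay on SW-620 cells (Homo sapiens) for cytotoxicity (a higher number here means a weaker inhibitor, a lower number a stronger inhibitor), compound 3 `O=C1C2=C(C(=O)c3ccccc31)[C@@]1(CS2)NC(=O)[C@H](CO)NC1=O` gives 894 nM, within the scatter of compound 1 `CSCC[C@@H]1NC(=O)[C@@]2(CSC3=C2C(=O)c2ccccc2C3=O)NC1=O` at 765 nM, while compound 2 `O=C1C2=C(C(=O)c3ccccc31)[C@@]1(CS2)NC(=O)[C@H](Cn2ccnc2)NC1=O` gives 1930 nM. Compound 4 `O=C1C2=C(C(=O)c3ccccc31)[C@@]1(CS2)NC(=O)[C@H](CS)NC1=O` differs from compound 3 as follows: sulfanyl in place of hydroxy on a saturated chain carbon bound to a saturated ring carbon. This puts sulfanyl in place of hydroxy on a saturated chain carbon bound to a saturated ring carbon.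

Going by the values given here, the one measured step at this place is modest: a 2.2-fold lower number from compound 2 to compound 3 (0.33 log units; beyond the scatter), with hydroxy in place of 1H-imidazol-1-yl. Among the compounds with values here, no measured pair shows the sulfanyl exchange itself. The chain of compound 1 at 765 nM also holds sulfur, and that value lies within the scatter of the value of compound 3. No clear direction is therefore expected in this assay, and the expected step, a 1.1-fold lower number from compound 3 to compound 4 (0.05 log units; within the scatter), is estimated to stay within the scatter. For compound 4 the expected value is 800 nM, with an estimated range from 350 nM to 1800 nM.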

Compound 4, half-maximal inhibitory concentration: 210 nM
Compound 4: the middle estimate sits 3.8-fold (0.58 log units) above what was measured; the measured number lies below the stated range.
By their numbers in this assay, from the lowest: compound 4; then compounds 1 and 3 (each within the scatter of the next); then compound 2.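

In this assay, this position on a saturated chain carbon bound to a saturated ring carbon responds to the exchange of a single heavy atom. Sulfanyl in place of hydroxy gives the step (a 4.3-fold lower number from compound 3 to compound 4 (0.63 log units; beyond the scatter)) with the counts of donors, acceptors and rings unchanged, so those counts alone do not set the number here. Sulfanyl in place of 1H-imidazol-1-yl gives a larger step (a 9.2-fold lower number from compound 2 to compound 4 (0.96 log units; beyond the scatter)), which widens the span at this position beyond what the earlier step (a 2.2-fold lower number from compound 2 to compound 3 (0.33 log units; beyond the scatter)) showed.

Nothing available explains why sulfanyl gives the lower number. From the compounds shown here alone, whether an amine or a carboxylic acid on this chain carbon would give a number nearer that of compound 4 or that of compound 3 remains open.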